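The source may hold more compounds than are shown below. What is called first, only, known or untested is meant among the compounds shown, and "the series" means these compounds.

Measured in a physicochemical assay for solubility, using the shake flask method, in phosphate buffer, measured as kinetic solubility, with a stated time of 20 h, at pH 6.5; a higher number here means a more soluble compound, a lower number a less soluble compound:

Compound 1 `FC1(F)CCC(c2nc3cnc(Nc4ccc(C(F)(F)F)cn4)cc3[nH]2)C1`: 120000 nM
Compound 2 `CC1(c2nc3cnc(Nc4ccc(C(F)(F)F)cn4)cc3[nH]2)CC1`: 188000 nM

Among the measured compounds shown here, these are the only two numbers available. They lie within the usual scatter of repeated measurements, so compound 2 cannot be ranked apart from compound 1 in this assay.

The next compound, compound 3 `FC(F)(F)c1ccc(Nc2cc3[nH]c(CC4CC4)nc3cn2)nc1`, keeps the shared core of compound 2 and rearranges one group. cyclopropylmethyl in place of 1-methylcyclopropyl on an aromatic carbon Cyclopropylmethyl takes the place of 1-methylcyclopropyl on an aromatic carbon between two ring nitrogen atoms. The atoms are the same, but they are joined differently.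

For the measured compounds named here, only one measured step bears on this change. The step of a 1.6-fold higher number from compound 1 to compound 2 (0.19 log units; within the scatter) involves a group on that same aromatic carbon and stays within the scatter. Going by the values given here, it is a different swap, and no measured compound carries cyclopropylmethyl, so it offers only weak guidance. On that evidence, no step beyond the scatter is expected in either direction.

The expected step is a 1.3-fold lower number from compound 2 to compound 3 (0.10 log units; within the scatter), which would remain within the scatter. The estimate for compound 3 is 150000 nM, with an expected range from 70000 nM to 300000 nM.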

Compound 3, solubility: 118000 nM
Beside the measured number, compound 3's estimate is 1.3-fold (0.10 log units) above it; the measured number falls inside the stated range.
By their numbers in this assay, from the lowest: compounds 3, 1 and 2 (each within the scatter of the next).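

In this assay, joining the same atoms differently, with cyclopropylmethyl in place of 1-methylcyclopropyl on the aromatic carbon between two ring nitrogen atoms, gives a 1.6-fold lower number from compound 2 to compound 3 (0.20 log units; within the scatter) and so leaves the two compounds indistinguishable. Among the compounds shown here, this is the first look at a group attached through a ring-bearing chain carbon rather than directly through a ring carbon, and that difference in attachment does not separate the compounds in this small set. Cyclopropylmethyl in place of 3,3-difluorocyclopentyl gives a 1.0-fold lower number from compound 1 to compound 3 (0.01 log units; within the scatter) as well, so all three groups shown at this position now lie within the scatter of one another, and no measurement shown offers an explanation for why they read alike.

The compounds shown leave open whether a group of a different kind on this carbon, such as an amine or a carboxylic acid, would give a step beyond the scatter in this assay. From the compounds shown here alone, a longer chain at this position, and any change elsewhere on the shared core, such as replacing the trifluoromethyl group, also remain open questions.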